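Acid-to-amide change on the carboxymethoxy side chain

A few compounds are considered here, and "the series" means these few. Any claim that something is new, unique, unknown or untested is made for them only; others in the source may bear on it.

Measured so far in an assay on a protein complex for inhibition of CDK8/Cyclin C (Homo sapiens), with a stated time of 1 h, tested at 10 uM; a higher number here means more inhibition at the concentration tested (going by the name of the read-out), a lower number less inhibition:
compound 1 `NC(=O)/C=C/c1ccncc1-c1ccc2ccccc2c1`: 102%
compound 2 `CNC(=O)/C=C/c1ccncc1-c1ccc2ccccc2c1`: 101%
compound 3 `O=C(O)COc1ccncc1-c1ccc2ccccc2c1`: 16%

Compound 3 stands lowest of the three numbers in this assay; its nearest neighbour is compound 2, and the gap a number 85 percentage points lower from compound 2 to compound 3 (beyond the scatter) lies beyond the scatter, as does a number 86 percentage points lower from compound 1 to compound 3 (beyond the scatter). Compound 4 `CNC(=O)COc1ccncc1-c1ccc2ccccc2c1` is not yet measured. It differs from compound 3 in one place: methylamino in place of hydroxy on a carbonyl carbon.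

Which measured steps bear on this? None of them is the same change. The step of a number 1 percentage points lower from compound 1 to compound 2 (within the scatter) shows that adding methyl on an amide-type nitrogen leaves the number unchanged, but that concerns a methyl on an existing amide, not the exchange of hydroxy for methylamino. The two large drops a number 86 percentage points lower from compound 1 to compound 3 (beyond the scatter) and a number 85 percentage points lower from compound 2 to compound 3 (beyond the scatter) each replace the carbamoylethenyl chain together with its amide, so they cannot separate the acid-to-amide part from the rest. The data therefore give no direct reading on this step.

Compound 4 is expected to sit somewhat above compound 3, with an expected step of a number 14 percentage points higher from compound 3 to compound 4 (beyond the scatter), since the amide-bearing compounds 1 and 2 gave the high numbers while the carboxy-bearing compound 3 gave the low one; the estimate for compound 4 is 30%, within 5% to 65%.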

Compound 4, a percentage reported as inhibition, at one concentration (the size of the read-out at that concentration, not a potency): 4%
For compound 4 the middle estimate is 26 percentage points above the measured one; measured number outside the range, below it.
By their numbers in this assay, from the lowest: compound 4; then compound 3; then compounds 2 and 1 (each within the scatter of the next).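

In this assay, methylamino in place of hydroxy on the carbonyl carbon gives a number 12 percentage points lower from compound 3 to compound 4 (beyond the scatter) and so the amide form of the carboxymethoxy side chain does not recover the high numbers; on this chain the acid reads slightly higher than the methyl amide. With the methylcarbamoyl end kept, (methylcarbamoyl)methoxy in place of 2-(methylcarbamoyl)ethenyl gives a number 97 percentage points lower from compound 2 to compound 4 (beyond the scatter) as its step, and the change from the 2-carbamoylethenyl chain gives a number 98 percentage points lower from compound 1 to compound 4 (beyond the scatter) as its step, so an amide end alone does not carry the high numbers. No measured evidence here accounts for these steps.

Still open, on these data alone, is how a carboxylic acid on the ethenyl chain would read, which would give the acid-to-amide step on that chain. Also open, as far as these compounds go, is whether a saturated propanamide chain, or a primary carbamoylmethoxy chain, keeps the number high or low.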